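Trifluoromethoxy onto the trifluoromethyl-bearing core

The source may report more compounds than this note shows. Statements on the series, on what has been measured and on what is new or still open speak of the compounds shown alone.

Of the compounds shown here, two are measured so far. Compound 1 `FC(F)(F)Oc1ccccc1-c1ccc2[nH]c(C3=NOC4(CCCCC4)C3)nc2c1` carries a trifluoromethoxy group on the pendant phenyl ring; in a functional assay on HEK293 cells for antagonist activity at transient receptor potential M8 protein (Canis lupus familiaris), read by FLIPR and calcium flux (on this read-out lower numbers stand for stronger inhibition and higher numbers for weaker inhibition), compound 1 gives 1.1 nM. Compound 2 `Fc1ccccc1-c1cc(C(F)(F)F)c2[nH]c(C3=NOC4(CCCCC4)C3)nc2c1` instead carries fluoro on that ring and a trifluoromethyl group on the shared core; in this assay compound 2 gives 1.7 nM. Of these two numbers compound 2 stands highest, with compound 1 as its nearest neighbour, and the two values lie within the scatter of each other, so no order between them is claimed. Compound 3 `FC(F)(F)Oc1ccccc1-c1cc(C(F)(F)F)c2[nH]c(C3=NOC4(CCCCC4)C3)nc2c1` joins both features: relative to compound 2 it shows (trifluoromethoxy in place of fluoro on an aromatic carbon), while the trifluoromethyl group of compound 2 is kept. For the measured compounds named here, no measured pair isolates this exact change, so the step in this assay is expected to be small, none beyond the scatter, with a slight lean toward a lower number because compound 1 gives 1.1 nM with the trifluoromethoxy group already in place. The step from compound 2 to compound 3 is estimated as a 1.3-fold lower number from compound 2 to compound 3 (0.12 log units; within the scatter). Compound 3 is expected at 1.3 nM, in a range from 0.5 nM to 3.5 nM.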

Compound 3, half-maximal inhibitory concentration: 1.2 nM
Compound 3: middle estimate off by 1.1-fold (0.03 log units), on the high side; low and high end bracket the measured number.
By their numbers in this assay, from the lowest: compounds 1, 3 and 2 (each within the scatter of the next).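

Trifluoromethoxy in place of fluoro on an aromatic carbon, ortho to a large group, reads in this assay as a 1.4-fold lower number from compound 2 to compound 3 (0.15 log units; within the scatter), which gives the series its first pair isolating this change and shows that, with the trifluoromethyl group kept on the shared core, this place accepts either group without a step beyond the scatter. Trifluoromethyl in place of hydrogen on an aromatic carbon of the core, with trifluoromethoxy kept on the pendant phenyl ring, reads as a 1.1-fold higher number from compound 1 to compound 3 (0.04 log units; within the scatter), so neither single change separates the compounds it links, and the two features can stand together without a step beyond the scatter. Nothing at hand gives a reason for either reading.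

Whether the trifluoromethyl step reads the same with fluoro on the pendant ring stays open, as the compounds shown offer no pair for it. Also open, going by these compounds, is whether this place keeps its numbers with a group of another kind, such as an amine or a carboxylic acid, since both groups compared here are fluorinated.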